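This account rests on a few compounds, and the source may have more. Where it says the series, first, only, none or still open, it means among the compounds named here.

Measured in a functional assay on MDA-MB-231 cells (Homo sapiens) for antiproliferative activity, read by MTT assay, with a stated time of 24 h; on this read-out lower numbers stand for stronger inhibition and higher numbers for weaker inhibition:

- compound 1 `O=C(NNc1ccc(F)cc1)c1cccc(NS(=O)(=O)c2cnc(O)nc2O)c1`: > 20000 nM
- compound 2 `O=C(NNC(=O)c1ccccc1Cl)c1ccc(NS(=O)(=O)c2cnc(O)nc2O)cc1`: 13900 nM

Compound 1 reads > 20000 nM, which is a limit of the assay and not a number. It therefore marks the starting point of this step without giving an exact potency. Among the two compounds tested, compound 2 provides the only actual number, 13900 nM.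

Compound 3 `O=C(NNC(=O)c1cccc(NS(=O)(=O)c2cnc(O)nc2O)c1)c1cccc(Cl)c1` is the next compound to be tested. It keeps the core of compound 1 but has (3-chlorophenyl)carbonyl in place of 4-fluorophenyl on an amine nitrogen. The new group brings a carbonyl into the molecule, while the ring count stays the same.

Among the compounds with values here, no step between two measured compounds is available as a guide, so this forecast is uncertain. In this assay, only a small shift toward stronger inhibition is expected, and compound 3 could also reach the assay limit. The expected change is an at least 1.4-fold lower number from compound 1 to compound 3 (0.15 log units; that floor lies within the scatter). The anchor for this expectation is compound 2 at 13900 nM. For compound 3, the estimated value is 14000 nM, with an expected range of 6000 nM to 30000 nM.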

Compound 3, half-maximal inhibitory concentration: 3180 nM
For compound 3 the middle estimate is 4.4-fold (0.64 log units) above the measured one, and the stated range ends above it.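

In this assay, putting (3-chlorophenyl)carbonyl in place of 4-fluorophenyl on an amine nitrogen gives an at least 6.2-fold lower number from compound 1 to compound 3 (0.79 log units; beyond the scatter). Within the data shown here, compound 1 and compound 2 differ in more than one place, so they offered no step to read, whereas this pair shows that the group on this nitrogen can shift the read-out beyond the usual scatter, toward stronger inhibition. The step is only a floor, and its true size stays open, because compound 1 stands at a limit of the assay and not at a number: the limit of > 20000 nM in this assay, at which 1 of the 3 values shown sits.

The change also does more than one thing at once: it adds a carbonyl to the chain and replaces the fluorine on the ring with a chlorine, and the compounds shown cannot separate these two parts. A (4-fluorophenyl)carbonyl group on the same nitrogen would test the carbonyl while keeping the original ring, and a plain phenylcarbonyl group would show how much of the effect remains with no halogen on the ring at all.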